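Replacing 2-chlorophenyl with 4-fluorophenyl: working notes

The compounds below may be only part of what the source reports. "The series", "measured", "known", "first", "only" and "open" are said of these compounds alone.

Measured in a functional assay on L1210 cells (Mus musculus) for antiproliferative activity; on this read-out lower numbers stand for stronger inhibition and higher numbers for weaker inhibition:
- Compound 1 `COc1cc(C(=O)c2sc(-c3ccc(-c4ccccc4)cc3)cc2N)cc(OC)c1OC`: > 10000 nM
- Compound 2 `COc1cc(C(=O)c2sc(-c3ccccc3Cl)cc2N)cc(OC)c1OC`: 20 nM

For the measured compounds named here, compound 2 gives 20 nM, the only actual number so far in this assay. Compound 1 reads > 10000 nM, which is a limit of the assay and not a number.

Compound 3 `COc1cc(C(=O)c2sc(-c3ccc(F)cc3)cc2N)cc(OC)c1OC` has not yet been measured. It carries 4-fluorophenyl in place of 2-chlorophenyl on an aromatic carbon, next to the ring sulfur: 4-fluorophenyl in place of 2-chlorophenyl on an aromatic carbon. Going by the values given here, no measured step covers this change, so the expectation rests on one number only. With compound 2 at 20 nM, a moderate loss seems more likely than a further gain. The expected change is a 3.0-fold higher number from compound 2 to compound 3 (0.48 log units; beyond the scatter), towards weaker inhibition in this assay. For compound 3 the estimated value is 60 nM, with an expected range of 12 nM to 400 nM.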

Compound 3, half-maximal inhibitory concentration: 20 nM
The estimate for compound 3 lay 3.0-fold (0.48 log units) above the measured number; measured number inside the range.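

In this assay, 4-fluorophenyl in place of 2-chlorophenyl on the aromatic carbon next to the ring sulfur gives no change at the digits printed from compound 2 to compound 3 (within the scatter), so at this position the two groups cannot be told apart in this read-out. Fluoro in place of phenyl on an aromatic carbon gives an at least 500-fold lower number from compound 1 to compound 3 (2.69 log units; beyond the scatter), so here the choice of group on the phenyl ring matters far more than the change from 2-chlorophenyl to 4-fluorophenyl does. The size of that step is only a bound, because compound 1 reads as a limit of the assay and not as a number: the limit of > 10000 nM in this assay, at which 1 of the 3 values shown sits.

Open, on these data alone, is what a methoxy or a trifluoromethyl on the phenyl ring would give in this read-out. Also open, as far as these compounds go, is whether a phenyl ring is needed at this position at all, as against a pyridine ring or a longer alkyl chain.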